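Swapping 3,4-Dihydroxyphenyl for 4-Bromophenyl

The source may hold more compounds than are shown below. What is called first, only, known or untested is meant among the compounds shown, and "the series" means these compounds.

For the measured compounds named here, in a functional assay on SK-OV-3 cells (Homo sapiens) for cytotoxicity (a higher number here means a weaker inhibitor of growth, a lower number a stronger inhibitor of growth), compound 2 `CSc1ccc(C2=C(c3ccc(O)c(O)c3)C(=O)N3CCCC3C2)cc1` gives 80000 nM, the higher of the two numbers so far, which makes it the weaker inhibitor of growth. Compound 1 `COc1ccc(C2=C(c3ccc(SC)cc3)CC3CCCN3C2=O)cc1Br` gives 3000 nM. Compound 3 `CSc1ccc(C2=C(c3ccc(Br)cc3)C(=O)N3CCCC3C2)cc1` has not yet been measured. It carries 4-bromophenyl in place of 3,4-dihydroxyphenyl on a double-bonded ring carbon. Going by the values given here, the one measured step at that ring carbon shows a 27-fold higher number from compound 1 to compound 2 (1.43 log units; beyond the scatter), a large change, with 3,4-dihydroxyphenyl in place of 3-bromo-4-methoxyphenyl. Read in reverse, that step suggests that removing 3,4-dihydroxyphenyl may lower the number by a similar amount, although 4-bromophenyl differs from the group in compound 1. The expected change is a large fall, an estimated 16-fold lower number from compound 2 to compound 3 (1.20 log units; beyond the scatter). Compound 3 is expected near 5000 nM, with an estimated range of 1500 nM to 20000 nM.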

Compound 3, concentration for 50% growth inhibition: 9000 nM
For compound 3 the middle estimate is 1.8-fold (0.26 log units) below the measured one; the range from low to high includes it.
By their numbers in this assay, from the lowest: compound 1; then compound 3; then compound 2.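

Replacing 3,4-dihydroxyphenyl with 4-bromophenyl at this ring carbon gives an 8.9-fold lower number from compound 2 to compound 3 (0.95 log units; beyond the scatter) in this assay, so the high number of compound 2 is tied to the 3,4-dihydroxyphenyl group rather than to the shared core. A simple ring carrying a single bromine recovers much of the growth inhibition, but not all of it: 4-bromophenyl in place of 3-bromo-4-methoxyphenyl gives a 3.0-fold higher number from compound 1 to compound 3 (0.48 log units; beyond the scatter) and leaves compound 1 the stronger inhibitor of growth of the two. No independent measurement explains these differences.

The compounds shown do not separate the effect of adding bromine from that of removing the two hydroxyl groups. As far as these compounds go, it also remains open how a plain phenyl ring, or a phenyl ring carrying an amine or a carboxylic acid, would behave at this ring carbon.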